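The source may hold more compounds than are shown below. What is called first, only, known or untested is meant among the compounds shown, and "the series" means these compounds.

Measured compounds:
- compound 1, `COc1cc(-c2nc3cc(/C=C4\SC(=O)NC4=O)ccc3[nH]2)cc(OC)c1OC`, 12000 nM
- compound 2, `COc1ccc(-c2nc3cc(/C=C4\SC(=O)NC4=O)ccc3[nH]2)cc1OC`, 8720 nM

Both numbers come from a functional assay on PC-3 cells (Homo sapiens) for inhibition, read by MTT assay, with a stated time of 48 h; on this read-out lower numbers stand for stronger inhibition and higher numbers for weaker inhibition. Among the compounds with values here, compound 1 has the higher of the two numbers, but the only measured step, a 1.4-fold lower number from compound 1 to compound 2 (0.14 log units; within the scatter), lies within the scatter, so the two compounds cannot be told apart on this read-out.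

Compound 3, `COc1cc(-c2nc3cc(/C=C4\SC(=O)N(Cc5cccc(C)c5)C4=O)ccc3[nH]2)cc(OC)c1OC`, has not yet been measured. It differs from compound 1 by 3-methylbenzyl in place of hydrogen on an amide-type nitrogen in a ring. Within the data shown here, no measured step touches this part of the shared core: the one step known concerns a methoxy on an aromatic ring, far from the amide-type nitrogen, and it was within the scatter. Among the measured compounds shown here, there is therefore no precedent in this data set for what a 3-methylbenzyl on that nitrogen does, in either direction.

Without such a precedent, compound 3 is expected to give 12000 nM in this assay, with a wide range of 2500 nM to 50000 nM, which amounts to an expected step of no change at the digits printed from compound 1 to compound 3 (within the scatter).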

Compound 3, half-maximal inhibitory concentration: 4370 nM
Beside the measured number, compound 3's estimate is 2.7-fold (0.44 log units) above it, and the stated range covers the measured number.
By their numbers in this assay, from the lowest: compounds 3, 2 and 1 (each within the scatter of the next, the first and the last beyond it).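

In this assay, replacing the hydrogen on the amide-type nitrogen with 3-methylbenzyl gives a 2.7-fold lower number from compound 1 to compound 3 (0.44 log units; beyond the scatter), a modest step towards stronger inhibition. The only earlier change, at a methoxy on an aromatic carbon, stayed within the scatter, so this nitrogen is the first position shown where a change clearly moves the number, and it tolerates a substituent carrying a whole extra aromatic ring without any loss of inhibition. Nothing in the data given explains the step.

From the compounds shown here alone, it remains open whether the gain needs the methyl group, or whether a plain benzyl would give the same number. Also open, going by these compounds, is how a carboxylic acid or an amine on a chain at the same nitrogen would behave, and whether 3-methylbenzyl gives a similar step on the core of compound 2.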